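This account rests on a few compounds, and the source may have more. Where it says the series, first, only, none or still open, it means among the compounds named here.

In a functional assay on cell membranes from cells (Erythrocyte, Homo sapiens), read by spectrophotometry, with a stated time of 30 min, tested at 100 ug/mL (a lower number here means a weaker effect, a higher number a stronger effect of the compound at the concentration tested), compound 1 `O=C1COc2ccccc2-c2ccccc2OCC(=O)NCc2ccc(cc2)-c2cccc(c2)-c2ccc(cc2)CN1` gives 93.8%, and compound 2 `O=C1NCc2ccc(cc2)-c2cccc(c2)-c2ccc(cc2)CNC(=O)c2cccc(c2)OCc2cc(cc([N+](=O)[O-])c2)COc2cccc1c2` gives 85.7%. For the measured compounds named here, these two numbers lie within the usual scatter of repeated measurements of each other, so compound 2 cannot be set apart from compound 1 on this evidence, and as the two compounds differ in more than one place no single structural step links them. Compound 3 `O=C1NCc2ccc(cc2)-c2cccc(c2)-c2ccc(cc2)CNC(=O)c2cccc(c2)OCc2cccc(c2)COc2cccc1c2` has not yet been measured. It differs from compound 2 in one place: hydrogen in place of nitro on an aromatic carbon. Going by the values given here, no measured pair shows what this change does, so the expectation for compound 3 rests on the numbers of compound 1, 93.8%, and compound 2, 85.7%, which both sit high in this assay. The expected step is a number 2.3 percentage points higher from compound 2 to compound 3 (within the scatter), none beyond the scatter. Compound 3 is therefore estimated at 88%, within a range from 75% to 97%.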

Compound 3, a percentage reported as activity, at one concentration (the size of the read-out at that concentration, not a potency): 83.1%
Compound 3: middle estimate off by 4.9 percentage points, on the high side, within the range that was stated.
By their numbers in this assay, from the lowest: compounds 3, 2 and 1 (each within the scatter of the next, the first and the last beyond it).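

With hydrogen in place of nitro on this aromatic carbon, this assay gives a step of a number 2.6 percentage points lower from compound 2 to compound 3 (within the scatter) and so does not set the two compounds apart. For the compounds shown here, this is the first pair here that differs in one place only, and it shows that the read-out at this single concentration stays high with or without the nitro group, so that group is not required for the effect seen. Nothing shown here bears on why the read-out holds at this position.

Still open, as far as these compounds go, is whether an amine or a carboxylic acid on the same carbon would leave the read-out just as high. From the compounds shown here alone, a single concentration gives the size of the effect and not a potency, so any difference between compound 2 and compound 3 at lower concentrations also remains open.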